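Bromo in Place of Ethoxy: Activity Expected to Return

The source may hold more compounds than are shown below. What is called first, only, known or untested is meant among the compounds shown, and "the series" means these compounds.

Three compounds share one core and differ only at one aromatic carbon. Compound 1 `C=CCOc1c(C)c(C)c2c(c1C)CCC(C)(COc1ccc(/C=C3\SC(=O)NC3=O)cc1)O2` gives 45% in a functional assay on MCF7 cells (Homo sapiens), tested at 2.5 uM; a higher number here means a weaker effect of the compound at the concentration tested, a lower number a stronger effect. Compound 2 `C=CCOc1c(C)c(C)c2c(c1C)CCC(C)(COc1ccc(/C=C3\SC(=O)NC3=O)cc1OC)O2` gives 34% in this assay. Compound 3 `C=CCOc1c(C)c(C)c2c(c1C)CCC(C)(COc1ccc(/C=C3\SC(=O)NC3=O)cc1OCC)O2` gives 107% in this assay, the highest of the three numbers and so the weakest effect: the step of a number 62 percentage points higher from compound 1 to compound 3 (beyond the scatter) and the step of a number 73 percentage points higher from compound 2 to compound 3 (beyond the scatter) are both large, whereas a number 11 percentage points lower from compound 1 to compound 2 (beyond the scatter) is modest. Compound 4 `C=CCOc1c(C)c(C)c2c(c1C)CCC(C)(COc1ccc(/C=C3\SC(=O)NC3=O)cc1Br)O2` has not yet been measured; it differs from compound 3 by bromo in place of ethoxy on an aromatic carbon. Among the measured compounds shown here, no measured step places a bromo on this carbon, so the steps that bear on the change are those that put the ethoxy there, a number 62 percentage points higher from compound 1 to compound 3 (beyond the scatter) and a number 73 percentage points higher from compound 2 to compound 3 (beyond the scatter). Taking the ethoxy away is expected to undo most of that rise, since compound 1 without any group on this carbon gives 45%. For compound 4 this is expected to mean a step of a number 57 percentage points lower from compound 3 to compound 4 (beyond the scatter). Compound 4 is therefore estimated to give 50%, within 20% to 85%.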

Compound 4, a percentage reported as activity, at one concentration (the size of the read-out at that concentration, not a potency): 102%
Compound 4: the middle estimate sits 52 percentage points below what was measured; the measured number lies above the stated range.
By their numbers in this assay, from the lowest: compound 2; then compound 1; then compounds 4 and 3 (each within the scatter of the next).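

In this assay, the step of a number 5 percentage points lower from compound 3 to compound 4 (within the scatter) shows that bromo, with one heavy atom and no hydrogen-bond acceptor, reads the same as ethoxy, with three heavy atoms and one acceptor, so the weak effect at this aromatic carbon does not belong to ethoxy alone. The steps of a number 57 percentage points higher from compound 1 to compound 4 (beyond the scatter) and a number 68 percentage points higher from compound 2 to compound 4 (beyond the scatter) are both large, which places bromo with ethoxy and apart from hydrogen and methoxy, and the position now sorts into two groups of two compounds rather than one outlier and two alike. Nothing available here accounts for why two such different groups read alike.

The compounds shown leave open where the division falls: whether fluoro, an amine or a carboxylic acid on this carbon would read with hydrogen and methoxy or with ethoxy and bromo. They also leave open whether a longer chain such as propoxy would read as ethoxy does.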